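A few compounds are considered here, and "the series" means these few. Any claim that something is new, unique, unknown or untested is made for them only; others in the source may bear on it.

Measured so far: compound 1 `COC(C)CO[C@H](CC=C(C)C)C1=CC(=O)c2c(O)ccc(O)c2C1=O` and compound 2 `CC(C)=CC[C@@H](OC(=O)CC(C)(O)C(C)C)C1=CC(=O)c2c(O)ccc(O)c2C1=O`.

In a functional assay on DU-145 cells (Homo sapiens) for cytotoxicity, read by MTT assay (on this read-out higher numbers stand for weaker inhibition and lower numbers for stronger inhibition), compound 1 gives 16600 nM and compound 2 gives 16900 nM. Compound 1 has the lowest of the two numbers, its nearest neighbour being compound 2, with a 1.0-fold higher number from compound 1 to compound 2 (0.01 log units; within the scatter). Compound 3 `CCCC(C)(O)CC(=O)O[C@H](CC=C(C)C)C1=CC(=O)c2c(O)ccc(O)c2C1=O` differs from compound 1 by (2-hydroxy-2-methylpentyl)carbonyl in place of 2-methoxypropyl on an oxygen on a saturated carbon. Among the compounds with values here, the one step that bears on this, the step with (2-hydroxy-2,3-dimethylbutyl)carbonyl in place of 2-methoxypropyl, was a 1.0-fold higher number from compound 1 to compound 2 (0.01 log units; within the scatter), so no step beyond the scatter is expected in this assay, in either direction. Compound 3 is therefore estimated at 16800 nM (range 8000 nM to 35000 nM), an expected 1.0-fold higher number from compound 1 to compound 3 (0.01 log units; within the scatter).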

Compound 3, half-maximal inhibitory concentration: 75000 nM
Beside the measured number, compound 3's estimate is 4.5-fold (0.65 log units) below it, and the stated range ends below it.
By their numbers in this assay, from the lowest: compounds 1 and 2 (each within the scatter of the next); then compound 3.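

In this assay, this oxygen does not tolerate every side chain alike: (2-hydroxy-2-methylpentyl)carbonyl in place of 2-methoxypropyl gives a 4.5-fold higher number from compound 1 to compound 3 (0.65 log units; beyond the scatter) and thus a change the earlier step did not show. Propyl in place of isopropyl on the saturated chain carbon gives a 4.4-fold higher number from compound 2 to compound 3 (0.65 log units; beyond the scatter) even though the rest of the ester stays the same, so the number here depends on the far end of the chain, not on the ester alone. No evidence at hand accounts for either step.

From the compounds shown here alone, whether an ethyl group, a longer chain or an amine at that carbon would restore or further raise the number remains open.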